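This account rests on a few compounds, and the source may have more. Where it says the series, first, only, none or still open, it means among the compounds named here.

Compound 1 `C[C@H](NC(=S)Nc1cc(C(F)(F)F)cc(C(F)(F)F)c1)c1nc2ccccc2[nH]1` gives 154000 nM in a functional assay on DU-145 cells (Homo sapiens) for cytotoxicity, read by MTT assay; on this read-out lower numbers stand for stronger inhibition and higher numbers for weaker inhibition. Compound 3 `CC(C)C[C@H](NC(=S)Nc1cc(C(F)(F)F)cc(C(F)(F)F)c1)c1nc2ccccc2[nH]1` carries the change isopropyl in place of hydrogen on a saturated chain carbon, two bonds along the chain from an amide-type nitrogen and an aromatic carbon and in this assay compound 3 gives 17200 nM, so the step of a 9.0-fold lower number from compound 1 to compound 3 (0.95 log units; beyond the scatter) is the only one of its kind measured so far. Compound 2 `C[C@@H](NC(=S)NCc1ccccc1)c1nc2ccccc2[nH]1` gives 28700 nM in this assay; the difference between the core of compound 2 and the core of compound 1 is not broken down here, and the values of compound 2 and compound 3 lie within the scatter of each other.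

Compound 4 `CC(C)C[C@@H](NC(=S)NCc1ccccc1)c1nc2ccccc2[nH]1` is not yet measured. It differs from compound 2 by isopropyl in place of hydrogen on a saturated chain carbon, two bonds along the chain from an amide-type nitrogen and an aromatic carbon, the same change as that from compound 1 to compound 3, at a place described in the same words. Going by the values given here, the step of a 7.2-fold lower number from compound 2 to compound 4 (0.86 log units; beyond the scatter) is expected, beside a 9.0-fold lower number from compound 1 to compound 3 (0.95 log units; beyond the scatter), on the single precedent only. Compound 4 is thus expected at about 4000 nM, between 1200 nM and 14000 nM.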

Compound 4, half-maximal inhibitory concentration: 21200 nM
For compound 4 the middle estimate is 5.3-fold (0.72 log units) below the measured one; the whole stated range lies below it.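

On the core of compound 2, isopropyl in place of hydrogen gives only a 1.4-fold lower number from compound 2 to compound 4 (0.13 log units; within the scatter) in this assay, so the large step on the core of compound 1 does not carry over. The two steps differ in size: the same change on two cores in this assay, a 9.0-fold lower number (0.95 log units; beyond the scatter) from compound 1 to compound 3 and a 1.4-fold lower number (0.13 log units; within the scatter) from compound 2 to compound 4, 6.6-fold (0.82 log units) apart, beyond the scatter of two such steps. These two pairs show that the step depends on the core in this series, but they do not show which feature of the cores is responsible or how the change would behave on a third core.

Open, going by these compounds, is how a longer chain, such as n-hexyl, would compare with isobutyl at this chain carbon on either core. Also open, on these data alone, is whether an amine or a carboxylic acid at the end of that chain would follow the pattern of either core.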